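The source may hold more compounds than are shown below. What is called first, only, known or untested is meant among the compounds shown, and "the series" means these compounds.

Compound 3 `COCc1ncc2cnnc(O)n12` and compound 1 `C=CCSc1nncc2cnc(COC)n12` share a core and differ in one place: allylsulfanyl in place of hydroxy on an aromatic carbon. In a functional assay for inhibition, with Homo sapiens as the target (on this read-out higher numbers stand for weaker inhibition and lower numbers for stronger inhibition), compound 1 gives 79000 nM. For compound 3 the assay reports only a limit, > 48000 nM. The step that the limit leaves unreadable from compound 3 to compound 1 therefore cannot be sized, because of the limit of > 48000 nM in this assay, at which 2 of the 3 values shown sit. Compound 2 `Cc1nc(C)n2c(O)nncc12` carries another core, and how the two cores differ is not broken down here. For compound 2 the assay again reports only a limit, > 48000 nM. Compound 4 `C=CCSc1nncc2c(C)nc(C)n12` is made from compound 2 by the same change: allylsulfanyl in place of hydroxy on an aromatic carbon. Going by the values given here, the step that the limit leaves unreadable from compound 2 to compound 4 is only an expectation, resting on compound 1 with 79000 nM as the sole readable value, so the estimate for compound 4 is 80000 nM, between 30000 nM and 250000 nM.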

Compound 4, half-maximal inhibitory concentration: 59000 nM
The estimate for compound 4 lay 1.4-fold (0.13 log units) above the measured number; low and high end bracket the measured number.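

The change from compound 2 to compound 4 cannot be sized, because compound 2 carries only a limit: the limit of > 48000 nM in this assay, at which 2 of the 4 values shown sit. The compounds shown leave open whether allylsulfanyl in place of hydroxy changes inhibition at all, on either core.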